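Boronic chalcone analogs and cytotoxicity toward non-tumour breast cells

A few compounds are considered here, and "the series" means these few. Any claim that something is new, unique, unknown or untested is made for them only; others in the source may bear on it.

Of the compounds shown here, two sharing one core have been measured in a toxicity assay on MCF-10A cells (Homo sapiens) for cytotoxicity, read by MTT assay, with a stated time of 48 h; on this read-out lower numbers stand for stronger inhibition and higher numbers for weaker inhibition. Compound 1 `O=C(/C=C/c1ccc2c(c1)B(O)OC2)c1ccccc1` gives 15900 nM, and compound 2 `O=C(/C=C/c1ccc2c(c1)B(O)OC2)c1ccc(Br)cc1` gives 27800 nM. Among the compounds with values here, compound 2 therefore carries the highest of the two numbers, but its only neighbour is compound 1, and the step of a 1.7-fold higher number from compound 1 to compound 2 (0.24 log units; within the scatter) stays within the scatter, so the two values cannot be ordered.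

Compound 3 `Cc1cccc(C(=O)/C=C/c2ccc3c(c2)B(O)OC3)c1` has not yet been measured in this assay. It differs from compound 2 by 3-methylphenyl in place of 4-bromophenyl on a carbonyl carbon. Within the data shown here, only one measured step, from compound 1 to compound 2, touches this part of the molecule, and it lay within the scatter; no measured step involves a methyl group. The author therefore expects no step beyond the scatter in this assay for compound 3, estimated as a 1.4-fold lower number from compound 2 to compound 3 (0.14 log units; within the scatter), giving an expected value of 20000 nM with a range from 8000 nM to 50000 nM.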

Compound 3, half-maximal inhibitory concentration: 15900 nM
The estimate for compound 3 lay 1.3-fold (0.10 log units) above the measured number; measured number inside the range.
By their numbers in this assay, from the lowest: compounds 1, 3 and 2 (each within the scatter of the next).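

In this assay, 3-methylphenyl in place of 4-bromophenyl on a carbonyl carbon gives a 1.7-fold lower number from compound 2 to compound 3 (0.24 log units; within the scatter), and adding a methyl group to the unsubstituted phenyl gives no change at the digits printed from compound 1 to compound 3 (within the scatter). The group on this carbonyl carbon has now been varied three ways, and each of the three compounds lies within the scatter of the others, so neither the bromo nor the methyl group separates any compound from the unsubstituted phenyl of compound 1. No accompanying evidence offers an explanation for these numbers.

On these data alone, it remains open whether any group at this place can move the number beyond the scatter, for example an amine, a carboxylic acid or a longer chain in place of the methyl of 3-methylphenyl. Also open, as far as these compounds go, is what a change to the shared core would do.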